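Swapping chloro for fluoro beside the phenol

The source may hold more compounds than are shown below. What is called first, only, known or untested is meant among the compounds shown, and "the series" means these compounds.

Measured compounds:
compound 1, `Cc1ccccc1N(C)C(=O)c1ccc(-c2ccccc2O)o1`, 1900 nM
compound 2, `Cc1ccccc1N(C)C(=O)c1ccc(-c2ccc(O)c(Cl)c2)o1`, 52 nM

These two compounds share the same core and were tested in an assay on T47D cells for inhibition of 17-beta-hydroxysteroid dehydrogenase type 1 (Homo sapiens), read by HPLC, with a stated time of 24 h; a higher number here means a weaker inhibitor, a lower number a stronger inhibitor. Compound 1 gives 1900 nM. Among the measured compounds shown here, compound 2 gives 52 nM, which is the lowest number of the two, meaning the stronger inhibitor; the only step among the measured pair, a 37-fold lower number from compound 1 to compound 2 (1.56 log units; beyond the scatter), is large and well beyond the scatter.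

The unmeasured compound 3, `Cc1ccccc1N(C)C(=O)c1ccc(-c2ccc(O)c(F)c2)o1`, differs from compound 2 in a single place: fluoro in place of chloro on an aromatic carbon. The halogen sits ortho to a hydroxy group and meta to a large group, exactly where the chloro stood in compound 2.

For the measured compounds named here, no measured step bears directly on this change. The step of a 37-fold lower number from compound 1 to compound 2 (1.56 log units; beyond the scatter) moved the hydroxy group and introduced the chloro at the same time, so it says nothing about trading one halogen for another at a fixed position. Going by the values given here, with no direct precedent, the expectation for compound 3 is a number close to compound 2, with a modest drift toward a higher number allowed, that is a 1.9-fold higher number from compound 2 to compound 3 (0.28 log units; within the scatter). Compound 3 is therefore estimated at 100 nM, within a range from 30 nM to 400 nM.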

Compound 3, half-maximal inhibitory concentration: 10 nM
For compound 3 the middle estimate is 10-fold (1.00 log units) above the measured one, outside the stated range (below it).
By their numbers in this assay, from the lowest: compound 3; then compound 2; then compound 1.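

In this assay the two halogens are not interchangeable at this position: with fluoro in place of chloro on an aromatic carbon ortho to a hydroxy group, there is a 5.2-fold lower number from compound 2 to compound 3 (0.72 log units; beyond the scatter) and a stronger inhibitor. The earlier pair could not show this, as the hydroxy group and the chloro changed together there, whereas here only the halogen differs and that single atom still moves the number beyond the scatter. The 3-fluoro-4-hydroxyphenyl group also gives the largest step among the three compounds, a 190-fold lower number from compound 1 to compound 3 (2.28 log units; beyond the scatter) in this series, but no measurement at hand explains why fluoro gives the lower number.

The compounds shown leave open how bromo, methyl or methoxy would compare at this position, and whether a plain hydrogen there would give a number above or below those of the two halogens. Every compound shown also carries a hydroxy group on this ring, and what an amine in its place would do remains an open question.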